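The source may hold more compounds than are shown below. What is called first, only, known or untested is meant among the compounds shown, and "the series" means these compounds.

For the measured compounds named here, in a functional assay on the whole organism for antagonist activity, with Mus musculus as the target (a lower number here means that less compound is needed, a higher number that more compound is needed for the effect), compound 2 `CCOC(=O)N(C)CC#CCn1ccnc1` gives 97 mg/kg, the only real number so far. Compound 1 `COC(=O)N(C)C(C)C#CCn1ccnc1` gives > 100 mg/kg, which is a limit of the assay and not a number. Compound 3 `CCOC(=O)N(C)C(C)C#CCn1ccnc1` differs from compound 2 in one place: methyl in place of hydrogen on a saturated chain carbon bound to an amide-type nitrogen and a triple-bonded carbon. Going by the values given here, no measured pair shows this change alone, so any forecast in this assay is uncertain. Compound 1 carries the same methyl but also differs from compound 3 elsewhere. The limit shown by compound 1 is > 100 mg/kg and offers no hint of a large gain. No step beyond the usual scatter is therefore expected, and the estimated change is a 1.1-fold lower number from compound 2 to compound 3 (0.03 log units; within the scatter). For compound 3 the expected value is 90 mg/kg, with an estimated range of 35 mg/kg to 220 mg/kg.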

Compound 3, dose for half-maximal effect: 66 mg/kg
For compound 3 the middle estimate is 1.4-fold (0.13 log units) above the measured one; the measured number falls inside the stated range.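

In this assay, for the compounds shown here, compounds 2 and 3 form the first measured pair that isolates methyl in place of hydrogen on a saturated chain carbon bound to an amide-type nitrogen and a triple-bonded carbon: the result is a 1.5-fold lower number from compound 2 to compound 3 (0.17 log units; within the scatter), so this methyl gives no step that stands clear of repeat-measurement noise. The other new comparison, methyl in place of hydrogen on a saturated chain carbon bound to an oxygen next to a carbonyl group, gives an at least 1.5-fold lower number from compound 1 to compound 3 (0.18 log units; that floor lies within the scatter). Compound 1 stands at a limit of the assay and not at a number, so that step is only a floor: the limit of > 100 mg/kg in this assay, at which 1 of the 3 values shown sits.

Going by these compounds, an ethyl group or a hydroxyl group on the chain carbon bound to the amide-type nitrogen remains open. So does a longer chain on the carbon bound to the oxygen next to the carbonyl group.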